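Swapping the Sulfonyl Aryl: Expected Liver Clearance

The compounds below may be only part of what the source reports. "The series", "measured", "known", "first", "only" and "open" are said of these compounds alone.

Measured so far:
Compound 1 `COc1ccc(S(=O)(=O)c2cnc3c(F)cccc3c2-c2cccc(F)c2)cc1` gives 3.03 mL/min in an ADME assay on microsomes from liver (Homo sapiens) for metabolic stability, tested at 2.5 uM; a lower number here means slower removal, a higher number faster removal of the compound.
Compound 2 `COc1ccc(-c2c(S(=O)(=O)c3ccc(OC)cc3)cnc3c(F)cccc23)cc1` gives 2.12 mL/min in this assay.

Going by the values given here, only two compounds have numbers so far, and they sit close together: the change a 1.4-fold lower number from compound 1 to compound 2 (0.16 log units; within the scatter) is the only measured step, and it lies inside the scatter of repeated measurements. Compound 1 therefore stands alongside compound 2 rather than apart from it, and neither can be called faster or slower cleared than the other.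

Compound 3 `O=S(=O)(c1ccc(F)c(Cl)c1)c1cnc2c(F)cccc2c1-c1cccc(F)c1` has not yet been measured. It differs from compound 1 in one place: 3-chloro-4-fluorophenyl in place of 4-methoxyphenyl on a sulfonyl sulfur. This change sits on the sulfonyl sulfur, whereas the measured step from compound 1 to compound 2 altered the group on the aromatic carbon. Among the compounds with values here, no measured step touches the position changed here, so there is no direct precedent for the direction or size of the effect in this assay.

With only a small, within-scatter step available elsewhere in the series, the expectation for compound 3 is a number close to that of compound 1, with a step of about a 1.1-fold higher number from compound 1 to compound 3 (0.02 log units; within the scatter) that is expected to stay within the scatter. Compound 3 is therefore estimated at 3.2 mL/min, with a range from 1.5 mL/min to 7 mL/min.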

Compound 3, intrinsic clearance in a liver preparation (reported as CLH), per the amount of preparation that the assay uses: 1.23 mL/min
The estimate for compound 3 lay 2.6-fold (0.42 log units) above the measured number; the measured number lies below the stated range.
By their numbers in this assay, from the lowest: compounds 3, 2 and 1 (each within the scatter of the next, the first and the last beyond it).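

The group on the sulfonyl sulfur does matter in this assay: with 3-chloro-4-fluorophenyl in place of 4-methoxyphenyl, the series shows its first step beyond the scatter, a 2.5-fold lower number from compound 1 to compound 3 (0.39 log units; beyond the scatter). The two groups share 8 heavy atoms and one six-membered aromatic ring of carbon only, so the swap replaces the oxygen-bearing methoxy part with fluorine and chlorine, and 1 hydrogen-bond acceptor gives way to 0. Nothing shown here explains why the number falls or which of these differences is responsible.

Because chlorine and fluorine enter together, the compounds shown cannot separate their contributions, and they also leave open whether the same swap would give a similar step with 4-methoxyphenyl rather than 3-fluorophenyl on the aromatic carbon, as in compound 2. On these data alone, it also remains unknown how the number would respond to a different kind of group on the sulfonyl sulfur, such as an aromatic ring carrying an amine or a carboxylic acid.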